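From (methylsulfonyl)methyl to prop-1-yn-1-yl on the shared core

The source may report more compounds than this note shows. Statements on the series, on what has been measured and on what is new or still open speak of the compounds shown alone.

In an ADME assay on L1210/0 cells (Mus musculus) for cytotoxicity, with a stated time of 48 h (on this read-out higher numbers stand for weaker inhibition and lower numbers for stronger inhibition), compound 1 (`O=c1[nH]c(=O)n([C@H]2C[C@H](O)[C@@H](CO)O2)cc1/C=N/O`) gives 15500 nM as its value. Compound 2 (`CS(=O)(=O)Cc1cn([C@H]2C[C@H](O)[C@@H](CO)O2)c(=O)[nH]c1=O`) shows only a limit (> 200000 nM) and not a number. Within the data shown here, the one measured step (an at least 12-fold higher number from compound 1 to compound 2 (1.11 log units; beyond the scatter)) is large and beyond the scatter, so changing the group on this aromatic carbon can move the number far. Compound 3 (`CC#Cc1cn([C@H]2C[C@H](O)[C@@H](CO)O2)c(=O)[nH]c1=O`) brings a further change (prop-1-yn-1-yl in place of (methylsulfonyl)methyl on an aromatic carbon), with prop-1-yn-1-yl in place of (methylsulfonyl)methyl on an aromatic carbon. A large step to a lower number is expected (an at least 6.6-fold lower number from compound 2 to compound 3 (0.82 log units; beyond the scatter)). Compound 3 is estimated at 30000 nM (expected range 5000 nM to 150000 nM).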

Compound 3, half-maximal inhibitory concentration: > 200000 nM
Compound 3 gave a limit, no number; the forecaster's own chance of this, stated with the estimate: 15%; at least 6.6-fold (0.82 log units) between middle value and limit.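

In this assay, prop-1-yn-1-yl on this aromatic carbon also ends at a limit and not a number, so the step between compound 2 and compound 3 cannot be read. The readable result is an at least 12-fold higher number from compound 1 to compound 3 (1.11 log units; beyond the scatter), and since the groups in that step have the same count of heavy atoms, that count alone does not separate them. Comparison stops at the same ceiling: the limit of > 200000 nM in this assay, at which 2 of the 3 values shown sit.

On these data alone, whether compound 2 and compound 3 truly differ stays open. So does whether an amine or a longer carbon chain on this aromatic carbon would give a number.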